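The source may report more compounds than this note shows. Statements on the series, on what has been measured and on what is new or still open speak of the compounds shown alone.

Compound 1 `COc1ccc(N2CCN(C3=CC(=O)c4ccccc4C3=O)CC2)cc1` gives 46100 nM
Compound 2 `O=C1C=C(N2CCN(c3ccccc3)CC2)C(=O)c2ccccc21` gives 9900 nM

Both values come from a functional assay on DU-145 cells (Homo sapiens) for inhibition, read by MTT assay, with a stated time of 72 h (on this read-out lower numbers stand for stronger inhibition and higher numbers for weaker inhibition), and no other read-out is at hand. Of the two, compound 2 stands lowest at 9900 nM and so marks the better end of this small set. Compound 3 `COc1cccc(N2CCN(C3=CC(=O)c4ccccc4C3=O)CC2)c1` has not yet been measured. It differs from compound 2 by methoxy in place of hydrogen on an aromatic carbon in a single place, with methoxy in place of hydrogen on an aromatic carbon. Among the compounds with values here, one measured step bears on this change, namely a 4.7-fold lower number from compound 1 to compound 2 (0.67 log units; beyond the scatter) when hydrogen takes the place of methoxy on an aromatic carbon. Read backwards, that modest step points to a higher number when a methoxy is added. However, compound 3 carries its methoxy at a different place on the ring from compound 1, and a single step is thin evidence. A rise somewhat smaller than the measured step is therefore expected, with a wide margin. The estimate is a 2.0-fold higher number from compound 2 to compound 3 (0.31 log units; beyond the scatter) as the expected step. Compound 3 is estimated at 20000 nM with 7000 nM to 55000 nM as its expected range.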

Compound 3, half-maximal inhibitory concentration: 15000 nM
Compound 3: the middle estimate sits 1.3-fold (0.12 log units) above what was measured; measured number inside the range.
By their numbers in this assay, from the lowest: compounds 2 and 3 (each within the scatter of the next); then compound 1.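

In this assay the change from phenyl to 3-methoxyphenyl gives a 1.5-fold higher number from compound 2 to compound 3 (0.18 log units; within the scatter), so with the methoxy meta to a large group, compound 3 cannot be told apart from the unsubstituted compound 2. The earlier step had shown only that compound 1, with its 4-methoxyphenyl, differs from compound 2; the new comparison shows that this difference does not hold for every methoxy on the ring, since shifting the group to the 3-methoxyphenyl arrangement gives a 3.1-fold lower number from compound 1 to compound 3 (0.49 log units; beyond the scatter). Among these compounds, then, the effect of adding methoxy depends on where it sits on the aromatic ring, and compound 1 is the one that stands apart, although nothing at hand explains why.

What the compounds shown leave open is whether the tolerance at this place extends beyond methoxy, for instance to an ethoxy group, a longer chain, an amine or a carboxylic acid. They also leave open whether any group at this place would give a number beyond the scatter from that of compound 2, in either direction.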